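Adding a Methoxy Group to a Weak Cytotoxic Compound

The source may report more compounds than this note shows. Statements on the series, on what has been measured and on what is new or still open speak of the compounds shown alone.

Compound 1 `COc1ccc(Nc2nc(-n3c(C)nc4ccccc43)cs2)cc1`: 52500 nM
Compound 2 `c1ccc(Nc2nc(-n3ccnc3)cs2)cc1`: > 100000 nM, a limit of the assay and not a number
Compound 3 `Cc1nc2ccccc2n1-c1csc(Nc2ccccc2)n1`: 50000 nM

All three were tested in a functional assay on RKO cells (Homo sapiens) for cytotoxicity, read by resazurin assay, with a stated time of 72 h; a higher number here means a weaker inhibitor, a lower number a stronger inhibitor. Compound 1 and compound 3 share one core and differ only by methoxy in place of hydrogen on an aromatic carbon; this gave a 1.1-fold higher number from compound 3 to compound 1 (0.02 log units; within the scatter). Compound 2 has a different core, and the difference between the two cores is not broken down here. For compound 2 the value is only (the limit of > 100000 nM in this assay, at which 1 of the 3 values shown sits). Compound 4 `COc1ccc(Nc2nc(-n3ccnc3)cs2)cc1` is not yet measured; it differs from compound 2 by methoxy in place of hydrogen on an aromatic carbon, the same change at the same place as before. Because a 1.1-fold higher number from compound 3 to compound 1 (0.02 log units; within the scatter) lay within the scatter, the expected step here is a step that the limit leaves unreadable from compound 2 to compound 4, so compound 4 is expected to remain at the limit as well. Compound 4 is therefore estimated at 110000 nM, from 45000 nM to 300000 nM.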

Compound 4, half-maximal inhibitory concentration: > 100000 nM
Compound 4: only a limit was reported; the forecaster's own chance of this, stated with the estimate: 70%; the middle value is on the limit's open side.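

Compound 2 and compound 4 both stand at a limit of this assay and not at a number, so the step between them cannot be read: the limit of > 100000 nM in this assay, at which 2 of the 4 values shown sit. Going by these compounds, whether methoxy changes cytotoxicity on the core of compound 2 stays open.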